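A few compounds are considered here, and "the series" means these few. Any claim that something is new, unique, unknown or untested is made for them only; others in the source may bear on it.

Compound 1 `Cc1cc(C(F)(F)F)cc(NC[C@@H]2CC3(CC3)CN2C(=O)c2nc(C)sc2-c2ccccc2)n1` gives 7.8 in a functional assay on CHO cells for antagonist activity at Orexin/Hypocretin receptor type 1 (Homo sapiens), read by FLIPR and calcium flux; a lower number here means a less potent compound, a higher number a more potent compound, by a factor of ten per unit of this negative logarithm.
Compound 2 `Cc1ccc(-n2nccn2)c(C(=O)N2CCC3(CC3)C[C@H]2CNc2cccc(C)n2)c1` gives 8.2 in this assay.
Compound 3 `O=C(c1ncccc1-c1ncccn1)N1CC2(CC2)C[C@H]1CNc1ccc(C(F)(F)F)cn1` gives 7.7 in this assay.

Among these three numbers, compound 1 stands second highest. Its gap to compound 3 lies within the scatter, so the two cannot be told apart, while compound 2 stands higher by a margin beyond the scatter. Compound 4 `Cc1nc(C(=O)N2CC3(CC3)C[C@H]2CNc2cc(C(F)(F)F)ccn2)c(-c2ccccc2)s1` differs from compound 1 in one place: hydrogen in place of methyl on an aromatic carbon. Within the data shown here, no measured pair shows this same change, so the expectation rests on the three measured compounds alone. A small step downward in this assay is expected, a number 0.20 log units lower from compound 1 to compound 4 (within the scatter), small enough that it may not show above the scatter. Compound 4 is therefore expected to give 7.6, with a range from 7.1 to 8.1.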

Compound 4, negative logarithm of the antagonist equilibrium constant: 8.2
Compound 4: middle estimate off by 0.60 log units, on the low side; the measured number lies above the stated range.
By their numbers in this assay, from the lowest: compounds 3 and 1 (each within the scatter of the next); then compounds 2 and 4 (each within the scatter of the next).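

In this assay, the change from 6-methyl-4-(trifluoromethyl)pyridin-2-yl to 4-(trifluoromethyl)pyridin-2-yl gives a number 0.40 log units higher from compound 1 to compound 4 (beyond the scatter), the first single-place step seen here. The methyl next to the ring nitrogen is therefore not needed for potency in this pair, and hydrogen at this place does better. This rests on one pair, and nothing available explains the step.

Going by these compounds, whether a chlorine atom, a methoxy group or an amine at this place would do as well remains open. So does whether removing this methyl has the same effect on a different core.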